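The source may report more compounds than this note shows. Statements on the series, on what has been measured and on what is new or still open speak of the compounds shown alone.

Measured in a functional assay on SW-620 cells (Homo sapiens) for cytotoxicity, read by MTT assay, with stated times of 4 h and 72 h, tested at 2 uM; a higher number here means a weaker inhibitor, a lower number a stronger inhibitor:
- compound 1 `Cc1cc(Nc2ccc(C(=O)/C=C/c3ccccc3)cc2)n2nc(SCc3nc4ccccc4[nH]3)nc2n1`: 130 nM
- compound 2 `Cc1cc(Nc2ccc(C(=O)/C=C/c3ccc4ccccc4c3)cc2)n2nc(SCc3nc4ccccc4[nH]3)nc2n1`: 5 nM
- compound 3 `Cc1cc(Nc2ccc(C(=O)/C=C/c3cccc(F)c3)cc2)n2nc(SCc3nc4ccccc4[nH]3)nc2n1`: 590 nM

In this assay, compound 3 has the highest of the three numbers, making it the weakest inhibitor so far. Compound 4 `Cc1cc(Nc2ccc(C(=O)/C=C/c3ccccc3Cl)cc2)n2nc(SCc3nc4ccccc4[nH]3)nc2n1` replaces its aryl group: 2-chlorophenyl in place of 3-fluorophenyl on a double-bonded chain carbon bound to a double-bonded chain carbon. The closest evidence is a 4.5-fold higher number from compound 1 to compound 3 (0.66 log units; beyond the scatter), a modest step for fluoro in place of hydrogen on an aromatic carbon. The large 26-fold lower number from compound 1 to compound 2 (1.41 log units; beyond the scatter) concerns naphthalen-2-yl and bears only weakly on this change. For the measured compounds named here, no measured compound carries chloro, so the direction is uncertain. A small expected move towards the unsubstituted compound 1 at 130 nM is tentatively assumed, giving an expected 2.0-fold lower number from compound 3 to compound 4 (0.29 log units; within the scatter). For compound 4 the estimate is 300 nM, with an expected range of 70 nM to 1200 nM.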

Compound 4, half-maximal inhibitory concentration: 680 nM
Compound 4: middle estimate off by 2.3-fold (0.36 log units), on the low side; the measured number falls inside the stated range.
By their numbers in this assay, from the lowest: compound 2; then compound 1; then compounds 3 and 4 (each within the scatter of the next).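

Replacing 3-fluorophenyl with 2-chlorophenyl on a double-bonded chain carbon leaves the number within the scatter (a 1.2-fold higher number from compound 3 to compound 4 (0.06 log units; within the scatter)), so these two aryl groups cannot be separated here. The step that brings in chloro (a 5.2-fold higher number from compound 1 to compound 4 (0.72 log units; beyond the scatter)) goes the same way as the fluoro step, and the distance to the naphthalen-2-yl compound stays large (a 140-fold higher number from compound 2 to compound 4 (2.13 log units; beyond the scatter)). No measurement on hand explains this grouping of the two halogen-bearing compounds.

As far as these compounds go, whether an amine or a carboxylic acid on this phenyl ring would follow the halogens remains open. So does whether a bicyclic group other than naphthalen-2-yl, such as quinolin-3-yl, would keep the low number.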